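Cyano to Methoxy in a Series Without Measurable Cytotoxicity

This account rests on a few compounds, and the source may have more. Where it says the series, first, only, none or still open, it means among the compounds named here.

The series was tested in a functional assay on T-24 cells (Homo sapiens) for cytotoxicity, read by CCK-8 assay, with a stated time of 24 h; on this read-out lower numbers stand for stronger inhibition and higher numbers for weaker inhibition. Compound 1 `C/C(=C\c1cc(-c2ccc(C)cc2)co1)C(N)=O` shows only a limit in this assay, > 50000 nM. Compound 2 `C/C(=C\c1cccc(-c2ccccc2)c1)C(N)=O` likewise reaches only a limit, > 50000 nM. Compound 3 `C/C(=C\c1cc(-c2ccc(C#N)cc2)cs1)C(N)=O` also gives a limit rather than a number, > 50000 nM. Among the measured compounds shown here, compound 3 therefore stands nowhere distinct among the three: every value shown is a limit, and all sit at the same point (the limit of > 50000 nM in this assay, at which 3 of the 3 values shown sit), so no step between measured compounds can be sized.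

Compound 4 `COc1ccc(-c2csc(/C=C(\C)C(N)=O)c2)cc1` differs from compound 3 in one place, methoxy in place of cyano on an aromatic carbon. For the measured compounds named here, with no measured step to lean on and three limits in hand, the expected change from compound 3 to compound 4 is none beyond the scatter, a step that the limit leaves unreadable from compound 3 to compound 4, and the most likely outcome for compound 4 is once more a limit. Compound 4 is estimated at 60000 nM, within a range from 20000 nM to 150000 nM.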

Compound 4, half-maximal inhibitory concentration: > 50000 nM
Compound 4 was reported as a limit; the forecaster's own chance of this, stated with the estimate: 80%; the middle value is on the limit's open side.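

Compound 3 and compound 4 both give only limits in this assay, so no step can be read between them: the limit of > 50000 nM in this assay, at which 4 of the 4 values shown sit. The compounds shown leave open whether any change to the shared core would give a measurable value in this assay.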